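The source may hold more compounds than are shown below. What is called first, only, known or untested is meant among the compounds shown, and "the series" means these compounds.

Series notes. Of the compounds shown here, two are measured so far in an assay on HeLa cells for inhibition of sphingosine-1-phosphate transporter SPNS2 (Mus musculus), read by LC-MS, tested at 2 uM; a higher number here means more inhibition at the concentration tested (going by the name of the read-out), a lower number less inhibition. Compound 1 `CCCCCCCCCCc1ccc(-c2noc(CCCN(C)C)n2)cc1` gives 8%, and compound 2 `CCCCCCCCCCc1ccc(-c2noc([C@H](CCCCN)NC(C)=O)n2)cc1` gives 40%. Among the measured compounds shown here, the one measured step, a number 32 percentage points higher from compound 1 to compound 2 (beyond the scatter), leaves compound 2 as the highest of the two numbers, with compound 1 the nearest and well separated from it. Compound 3 `CCCCCCCCCCc1ccc(-c2noc(CC(O)CNCC)n2)cc1` is not yet measured. Its change from compound 2 is 3-(ethylamino)-2-hydroxypropyl in place of 1-acetamido-5-aminopentyl on an aromatic carbon. For the measured compounds named here, no measured step covers this exchange directly; the step from compound 1 to compound 2 bears on it only in that both changes sit on the same aromatic carbon, and that step was large. The chain entering compound 3 resembles the 3-(dimethylamino)propyl of compound 1 more than the 1-acetamido-5-aminopentyl of compound 2, so a downward step is expected, a number 20 percentage points lower from compound 2 to compound 3 (beyond the scatter), though smaller than the measured one. Compound 3 is estimated at 20%, within 5% to 38%.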

Compound 3, a percentage reported as inhibition, at one concentration (the size of the read-out at that concentration, not a potency): 5%
Compound 3: middle estimate off by 15 percentage points, on the high side; the range from low to high includes it.
By their numbers in this assay, from the lowest: compounds 3 and 1 (each within the scatter of the next); then compound 2.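

In this assay the exchange of 1-acetamido-5-aminopentyl for 3-(ethylamino)-2-hydroxypropyl on this aromatic carbon gives a number 35 percentage points lower from compound 2 to compound 3 (beyond the scatter) and so shows that a second short amine chain also fails to keep the level of compound 2. Read as 2-(ethylamino)-1-hydroxyethyl in place of 2-(dimethylamino)ethyl on a saturated chain carbon bound to an aromatic carbon, the other new comparison gives a number 3 percentage points lower from compound 1 to compound 3 (within the scatter) and so does not separate these two short chains, which leaves 1-acetamido-5-aminopentyl alone in standing apart among the three compounds. No measurement at hand accounts for this difference.

From the compounds shown here alone, it remains open whether the acetamido group, the terminal amine or the chain length in compound 2 matters most. Also open, going by these compounds, is how a guanidine or a pyrrolidine ring would read at this place.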